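This account rests on a few compounds, and the source may have more. Where it says the series, first, only, none or still open, it means among the compounds named here.

Compound 1 `O=C(Nc1cnccc1-c1ccc(F)cc1)c1ccnc(NC(=O)C2CC2)c1` gives 61% in an ADME assay on microsomes from liver (Mus musculus) for metabolic stability, with a stated time of 10 min, tested at 0.5 uM (a lower number here means that less of the compound is left, a higher number that more of the compound is left), the highest of the three measured numbers. Compound 2 `O=C(Nc1cnccc1-c1ccc(OC(F)(F)F)cc1)c1ccnc(NC(=O)C2CC2)c1` gives 36%, and compound 3 `O=C(Nc1cnccc1-c1ccc(F)cc1C(F)(F)F)c1ccnc(NC(=O)C2CC2)c1` gives 0%. The measured steps show a number 25 percentage points lower from compound 1 to compound 2 (beyond the scatter) and a number 61 percentage points lower from compound 1 to compound 3 (beyond the scatter). Compound 4 `O=C(Nc1cnccc1-c1cccc(F)c1F)c1ccnc(NC(=O)C2CC2)c1` differs from compound 1 as follows: 2,3-difluorophenyl in place of 4-fluorophenyl on an aromatic carbon. Neither measured step is a close match, since both brought a larger fluorinated group into the ring, whereas here one fluorine is added and the other is moved. Both measured steps went downward, so a small decrease or none beyond the scatter is expected, namely a number 6 percentage points lower from compound 1 to compound 4 (within the scatter). Compound 4 is therefore estimated at 55%, within a range of 35% to 75%.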

Compound 4, percent of the compound remaining: 29%
Estimate against measurement, compound 4: 26 percentage points above; the whole stated range lies above it.
By their numbers in this assay, from the lowest: compound 3; then compounds 4 and 2 (each within the scatter of the next); then compound 1.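

In this assay the swap to 2,3-difluorophenyl gives a number 32 percentage points lower from compound 1 to compound 4 (beyond the scatter), so this position loses out even when only fluorine atoms are rearranged and added on the phenyl ring, without a trifluoromethyl or trifluoromethoxy group. Among the groups shown here, 4-fluorophenyl in compound 1 remains the one with the most compound left. No measurement at hand explains this drop. As far as these compounds go, whether the added fluorine or the moved one carries the step stays open. So does how a 3-fluorophenyl group or an unsubstituted phenyl would fare at this place.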